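The source may report more compounds than this note shows. Statements on the series, on what has been measured and on what is new or still open speak of the compounds shown alone.

Measured compounds in a functional assay on HeLa cells (Homo sapiens) for cytotoxicity, read by cell counting, with a stated time of 4 days; on this read-out higher numbers stand for weaker inhibition and lower numbers for stronger inhibition:
compound 1 `CC(C)(C)c1ccc(CN2C(=O)S/C(=C\c3ccc(N)cc3)C2=O)cc1`: 53000 nM
compound 2 `Nc1ccc(/C=C2\SC(=O)N(Cc3ccc(Cl)cc3)C2=O)cc1`: 77000 nM
compound 3 `Nc1ccc(/C=C2\SC(=O)N(Cc3cccc(F)c3)C2=O)cc1`: 250000 nM

Compound 3 gives the highest of the three numbers, so the weakest inhibition of the set; its nearest neighbour is compound 2 and the furthest is compound 1, both gaps being beyond the scatter.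

Compound 4 `Nc1ccc(/C=C2\SC(=O)N(Cc3ccccc3)C2=O)cc1` is the unmeasured analogue. It differs from compound 3 by hydrogen in place of fluoro on an aromatic carbon.

Going by the values given here, two measured steps bear on this, both on the same benzyl substituent of the shared core: a 1.5-fold higher number from compound 1 to compound 2 (0.16 log units; within the scatter), which lies within the scatter, and a 3.2-fold higher number from compound 2 to compound 3 (0.51 log units; beyond the scatter), which is modest and beyond it. Among the compounds with values here, no measured step removes a substituent outright, so the size of the present change is only loosely bounded. Given that compound 2 and compound 3 sit within a modest gap of each other, the step of a 1.7-fold lower number from compound 3 to compound 4 (0.22 log units; within the scatter) is expected to be small, most likely a slight lowering of the number, not reliably beyond the scatter.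

For compound 4 the estimated value in this assay is 150000 nM, with a range of 60000 nM to 400000 nM.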

Compound 4, half-maximal inhibitory concentration: 46000 nM
Compound 4: middle estimate off by 3.3-fold (0.51 log units), on the high side; the whole stated range lies above it.
By their numbers in this assay, from the lowest: compounds 4, 1 and 2 (each within the scatter of the next); then compound 3.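

In this assay, hydrogen in place of fluoro, on a carbon meta to a large group, gives a 5.4-fold lower number from compound 3 to compound 4 (0.74 log units; beyond the scatter), so the high number of compound 3 goes with the 3-fluorophenyl group and not with the benzyl framework as such. Going by these compounds alone, the unsubstituted ring does not separate from the chloro or tert-butyl analogues: a 1.7-fold lower number from compound 2 to compound 4 (0.22 log units; within the scatter) and a 1.2-fold lower number from compound 1 to compound 4 (0.06 log units; within the scatter) both lie within the scatter, which leaves compound 3 as the one compound apart and the weakest of the four. Nothing at hand explains this behaviour of fluoro at this place.

Compound 3 is the only fluoro compound shown, so this reading rests on a single compound. As far as these compounds go, whether a methoxy or a trifluoromethyl group at the same place tracks fluoro or hydrogen stays open.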